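A few compounds are considered here, and "the series" means these few. Any claim that something is new, unique, unknown or untested is made for them only; others in the source may bear on it.

The measured compounds in an assay on cells for antagonist activity at transient receptor potential cation channel subfamily V member 1 (Homo sapiens), read by FLIPR and calcium flux, with a stated time of 6 min (on this read-out lower numbers stand for stronger inhibition and higher numbers for weaker inhibition), are these:
Compound 1, `CC(C(=O)NCc1ccc(C(C)(C)C)nc1N1CCCC1)c1ccc(NS(C)(=O)=O)c(F)c1`, gives 1.2 nM.
Compound 2, `CCCCCCSc1nc(C(C)(C)C)ccc1CNC(=O)C(C)c1ccc(NS(C)(=O)=O)c(F)c1`, gives 1.5 nM.
Compound 3, `CC(C(=O)NCc1ccc(C(C)(C)C)cc1N1CCN(c2ccccc2)CC1)c1ccc(NS(C)(=O)=O)c(F)c1`, gives 0.8 nM.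

All three share the same propanamide core joined to the fluorinated methanesulfonamide side, and differ only in the group on the aromatic ring that carries the tert-butyl group. Compound 3 sits with its number separated from compound 1 and from compound 2 by less than the usual scatter, so nothing in the three values sets one compound apart from the others.

Compound 4, `CC(C(=O)NCc1ccc(C(C)(C)C)cc1OCc1ccccc1)c1ccc(NS(C)(=O)=O)c(F)c1`, carries one change against compound 3: benzyloxy in place of 4-phenylpiperazin-1-yl on an aromatic carbon. A single measured step bears on this change, since it also exchanges the group at that position of the shared core: a 1.3-fold higher number from compound 1 to compound 2 (0.10 log units; within the scatter). That exchange of a ring for a chain at the same position left the number within the scatter, which suggests that the position tolerates quite different groups. The exchange in compound 4 is, however, a different one, and a smaller group enters, so a modest weakening beyond the scatter cannot be ruled out. Compound 4 is therefore expected to give about 2 nM, within a range from 0.6 nM to 8 nM. The expected step is a 2.5-fold higher number from compound 3 to compound 4 (0.40 log units; beyond the scatter).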

Compound 4, inhibition constant: 2.9 nM
The estimate for compound 4 lay 1.5-fold (0.16 log units) below the measured number; the range from low to high includes it.
By their numbers in this assay, from the lowest: compounds 3, 1, 2 and 4 (each within the scatter of the next, the first and the last beyond it).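

In this assay, benzyloxy in place of 4-phenylpiperazin-1-yl on this aromatic carbon gives a 3.6-fold higher number from compound 3 to compound 4 (0.56 log units; beyond the scatter) and is the only step shown at this position that lies beyond the scatter, though it is modest. The other step at this position is a 1.3-fold higher number from compound 1 to compound 2 (0.10 log units; within the scatter) and stays within the scatter on the core of compound 1, so the new result shows that this position does not treat every exchange alike, while the shift remains small for a change that removes the six-membered non-aromatic ring with its two nitrogen atoms and brings in a smaller group with one oxygen atom. Nothing measured here says which part of this exchange accounts for the step.

The compounds shown leave open whether the step follows the piperazine ring, its nitrogen atoms or the oxygen atom of benzyloxy, which a morpholin-4-yl or piperidin-1-yl group at this place could help to separate. They also leave open how this position would respond to a primary amine or a carboxylic acid, and whether the same exchange would give a similar step on the core of compound 1.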